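The source may report more compounds than this note shows. Statements on the series, on what has been measured and on what is new or still open speak of the compounds shown alone.

Three compounds share one core and differ only in the group on the carbonyl carbon of the amide. Compound 1 `CCCCC(=O)Nc1ccc(N2CCN(c3ccc(OC[C@@H]4CO[C@@](Cn5cncn5)(c5ccc(Cl)cc5Cl)O4)cc3)CC2)cc1` carries a butyl group there, and in a functional assay on HepG2 cells (Homo sapiens) for inhibition, read by MTT assay, with a stated time of 48 h (a lower number here means a stronger inhibitor, a higher number a weaker inhibitor), compound 1 gives 14100 nM. Compound 2 `O=C(CC1CCOCC1)Nc1ccc(N2CCN(c3ccc(OC[C@@H]4CO[C@@](Cn5cncn5)(c5ccc(Cl)cc5Cl)O4)cc3)CC2)cc1` carries (oxan-4-yl)methyl, and in this assay compound 2 gives 21100 nM. Compound 3 `O=C(Nc1ccc(N2CCN(c3ccc(OC[C@@H]4CO[C@@](Cn5cncn5)(c5ccc(Cl)cc5Cl)O4)cc3)CC2)cc1)c1ccc(F)c(F)c1` carries 3,4-difluorophenyl, and in this assay compound 3 gives 19900 nM. Compound 2 has the highest of the three figures, but the gap to compound 3 is a 1.1-fold lower number from compound 2 to compound 3 (0.03 log units; within the scatter) and the remaining step is a 1.5-fold higher number from compound 1 to compound 2 (0.18 log units; within the scatter), so the three sit together.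

Compound 4 `Cc1ccc(C(=O)Nc2ccc(N3CCN(c4ccc(OC[C@@H]5CO[C@@](Cn6cncn6)(c6ccc(Cl)cc6Cl)O5)cc4)CC3)cc2)o1` differs from compound 2 by 5-methylfuran-2-yl in place of (oxan-4-yl)methyl on a carbonyl carbon. The step that bears most on it is the exchange of the same (oxan-4-yl)methyl for an aromatic ring, a 1.1-fold lower number from compound 2 to compound 3 (0.03 log units; within the scatter), and the exchange of butyl for an aromatic ring, a 1.4-fold higher number from compound 1 to compound 3 (0.15 log units; within the scatter), was likewise within the scatter. He therefore expects no step beyond the scatter in this assay, with a 1.1-fold lower number from compound 2 to compound 4 (0.05 log units; within the scatter) as the estimated move. For compound 4 he estimates 19000 nM, with a range from 8000 nM to 45000 nM.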

Compound 4, half-maximal inhibitory concentration: 8700 nM
Estimate against measurement, compound 4: 2.2-fold (0.34 log units) above; measured number inside the range.
By their numbers in this assay, from the lowest: compounds 4, 1, 3 and 2 (each within the scatter of the next, the first and the last beyond it).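

Among these compounds, with 5-methylfuran-2-yl on the carbonyl carbon, the group at this position produces steps beyond the scatter for the first time in this assay: the change gives a 2.4-fold lower number from compound 2 to compound 4 (0.38 log units; beyond the scatter) and a 2.3-fold lower number from compound 3 to compound 4 (0.36 log units; beyond the scatter), both modest. Replacing (oxan-4-yl)methyl or 3,4-difluorophenyl therefore moves the number, but replacing butyl does not, with a 1.6-fold lower number from compound 1 to compound 4 (0.21 log units; within the scatter) lying within the scatter, so compound 1 goes against any simple split between the aromatic ring of compound 4 and the other groups. Nothing measured here explains these differences. The compounds shown leave open whether the steps follow the furan ring or its methyl group, which a plain furan-2-yl or a 5-methylthiophen-2-yl would help to separate. They also leave open how an amine or a carboxylic acid on the group at this carbonyl carbon would read in this assay.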